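The source may report more compounds than this note shows. Statements on the series, on what has been measured and on what is new or still open speak of the compounds shown alone.

Measured so far:
compound 1 `CC(=O)Nc1ccc(S(=O)(=O)NNC(=O)c2cccnc2Nc2ccc(Cl)cc2)cc1`: > 100000 nM in a functional assay on HT-29 cells (Homo sapiens) for antiproliferative activity; a lower number here means that less compound is tolerated, a higher number that more compound is tolerated
compound 2 `O=C(NNS(=O)(=O)c1ccc(F)cc1)c1cccnc1Nc1ccc(Cl)cc1Cl`: > 100000 nM in this assay

The reading for compound 1 is a limit of this assay, not a number. The reading for compound 2 is likewise a limit. Compound 1 therefore stands only at the limit of > 100000 nM in this assay, at which 2 of the 2 values shown sit, with no value of its own to place it further. Compound 3 `O=C(NNS(=O)(=O)c1ccc(Cl)cc1Cl)c1cccnc1Nc1ccc(Cl)cc1` carries 2,4-dichlorophenyl in place of 4-acetamidophenyl on a sulfonyl sulfur. Within the data shown here, no measured pair differs in a single place, so no step size is known. The expected step is a number no higher from compound 1 to compound 3 (the limit leaves the size open), none beyond the scatter. Compound 3 is estimated at 100000 nM, range 30000 nM to 300000 nM, most likely again reported only as a limit.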

Compound 3, concentration lethal to 50% of the cells: > 100000 nM
Compound 3 gave a limit, no number; the forecaster's own chance of this, stated with the estimate: 70%; the middle value sits exactly at the limit.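

Compound 1 and compound 3 both read as limits, so no step can be read between them: the limit of > 100000 nM in this assay, at which 3 of the 3 values shown sit. The compounds shown leave open whether any group on the sulfonyl sulfur gives a number rather than a limit in this assay.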